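A few compounds are considered here, and "the series" means these few. Any claim that something is new, unique, unknown or untested is made for them only; others in the source may bear on it.

In a functional assay on SNU-638 cells (Homo sapiens) for antiproliferative activity, read by sulforhodamine B assay, with a stated time of 72 h (on this read-out lower numbers stand for stronger inhibition and higher numbers for weaker inhibition), compound 1 (`COc1ncc(-c2ccc3c(c2)N(Cc2ccc(F)cc2)C(=O)CO3)cc1NS(=O)(=O)c1ccc(F)cc1F`) gives 7840 nM in this series, and compound 2 (`COc1ncc(-c2ccc3c(c2)N(Cc2ccncc2)C(=O)CO3)cc1NS(=O)(=O)c1ccc(F)cc1F`) gives 6960 nM on the same read-out. Compound 3 (`CCCCS(=O)(=O)Nc1cc(-c2ccc3c(c2)N(Cc2ccncc2)C(=O)CO3)cnc1OC`) gives 46500 nM as the highest of the three numbers, which makes it the weakest of them. The measured move to it, a 6.7-fold higher number from compound 2 to compound 3 (0.82 log units; beyond the scatter), lies at the sulfonyl sulfur and not at the place changed next. The change to compound 4 (`CCCCS(=O)(=O)Nc1cc(-c2ccc3c(c2)N(CCCn2ccccc2=O)C(=O)CO3)cnc1OC`) is a group of 9 heavy atoms (7 carbon, 1 nitrogen, 1 oxygen; one six-membered aromatic ring with 1 hetero atom) in place of a group of 6 heavy atoms (5 carbon, 1 nitrogen; one six-membered aromatic ring with 1 hetero atom), on a saturated chain carbon bound to an amide-type nitrogen in a ring and the butyl on the sulfonyl sulfur stays. For the measured compounds named here, the one measured step at that place is a 1.1-fold lower number from compound 1 to compound 2 (0.05 log units; within the scatter) and it exchanges different groups, so it offers only limited guidance. Going by the values given here, no measured compound carries the entering group. In this assay no step beyond the scatter is therefore expected, and the estimated step is a 1.2-fold lower number from compound 3 to compound 4 (0.07 log units; within the scatter) on this reasoning. Compound 4 is thus estimated at 40000 nM with an expected range from 14000 nM to 110000 nM in all.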

Compound 4, half-maximal inhibitory concentration: 44300 nM
Compound 4: middle estimate off by 1.1-fold (0.04 log units), on the low side; measured number inside the range.
By their numbers in this assay, from the lowest: compounds 2 and 1 (each within the scatter of the next); then compounds 4 and 3 (each within the scatter of the next).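

In this assay, the step at the saturated chain carbon bound to an amide-type nitrogen in a ring (a 1.0-fold lower number from compound 3 to compound 4 (0.02 log units; within the scatter)) shows that, with butyl on the sulfonyl sulfur, the group of 9 heavy atoms can replace pyridin-4-yl with no change beyond the scatter. For the compounds shown here, the only earlier step at this place (a 1.1-fold lower number from compound 1 to compound 2 (0.05 log units; within the scatter)) was read with 2,4-difluorophenyl on the sulfonyl sulfur and exchanged different groups, so the number has now stayed within the scatter at this place with each of the two sulfonyl substituents. Nothing measured here accounts for this lack of response.

From the compounds shown here alone, whether the group of 9 heavy atoms would also leave the number unchanged with 2,4-difluorophenyl on the sulfonyl sulfur remains open. So does whether an amine or a carboxylic acid at this place would move the number beyond the scatter.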